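The compounds below may be only part of what the source reports. "The series", "measured", "known", "first", "only" and "open" are said of these compounds alone.

Measured compounds in a functional assay on HL-60 cells (Homo sapiens) for inhibition, read by MTT assay, with a stated time of 72 h; on this read-out higher numbers stand for weaker inhibition and lower numbers for stronger inhibition:
- compound 1 `Cc1nc(-c2ccc(F)cc2)c(C(=O)N2CCN(c3cccc(Cl)c3)CC2)o1`: 40.1 nM
- compound 2 `COc1cc(OC)cc(N2CCN(C(=O)c3oc(C)nc3-c3ccc(F)cc3)CC2)c1`: 38.5 nM
- compound 3 `COc1cccc(N2CCN(C(=O)c3oc(C)nc3-c3ccc(F)cc3)CC2)c1`: 112 nM

Compound 1 stands second highest of the three numbers in this assay. Its nearest neighbour is compound 2, with a 1.0-fold lower number from compound 1 to compound 2 (0.02 log units; within the scatter), so the two cannot be ordered. Compound 3 is furthest, with a 2.8-fold higher number from compound 1 to compound 3 (0.45 log units; beyond the scatter), and from compound 2 the gap is a 2.9-fold higher number from compound 2 to compound 3 (0.46 log units; beyond the scatter). All three measured steps change only the aryl group on the amine nitrogen in the ring; the group on the shared core's five-membered ring is the same in each.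

Compound 4 `Cc1nc(-c2cccc(F)c2)c(C(=O)N2CCN(c3cccc(Cl)c3)CC2)o1` differs from compound 1 by 3-fluorophenyl in place of 4-fluorophenyl on an aromatic carbon. Going by the values given here, no measured step touches this position, so none bears directly on the change; the only guide is that the series as a whole sits within a narrow band in this assay. The expectation for compound 4 is therefore a step of a 1.1-fold higher number from compound 1 to compound 4 (0.05 log units; within the scatter), that is, nothing clearly beyond the scatter in either direction. Compound 4 is estimated at 45 nM in this assay, with a range of 15 nM to 150 nM.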

Compound 4, half-maximal inhibitory concentration: 33.7 nM
Estimate against measurement, compound 4: 1.3-fold (0.13 log units) above; low and high end bracket the measured number.
By their numbers in this assay, from the lowest: compounds 4, 2 and 1 (each within the scatter of the next); then compound 3.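

In this assay, exchanging 4-fluorophenyl for 3-fluorophenyl on the aromatic carbon next to the ring nitrogen gives a 1.2-fold lower number from compound 1 to compound 4 (0.08 log units; within the scatter) and so leaves compound 1 and compound 4 unordered. Going by these compounds alone, this is the first reading at this position of the shared core, since the earlier steps changed only the aryl group on the amine nitrogen in the ring. With the 3-chlorophenyl group held fixed, moving the fluorine within this aryl group produces no step beyond the scatter. Nothing available explains why the two compounds read alike.

Still open, on these data alone, is how a phenyl group carrying a carboxylic acid or a dimethylamino group would read at this position. Also open, as far as these compounds go, is whether 3-fluorophenyl reads the same alongside the 3,5-dimethoxyphenyl group of compound 2.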